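A Smaller Ring on the Amide Nitrogen

The compounds below may be only part of what the source reports. "The series", "measured", "known", "first", "only" and "open" are said of these compounds alone.

Two measured compounds share one core and differ only in the group carried on an amide-type nitrogen. Compound 1 `CN1CCC(NC(=O)c2ccncc2Nc2cc(-c3ccc4ccn(C)c4c3)c3nccnc3c2)CC1` carries 1-methylpiperidin-4-yl there; in an assay for inhibition of 6-phosphofructo-2-kinase/fructose-2,6-bisphosphatase 3 (Homo sapiens), read by ADP-Glo, with a stated time of 2 h (on this read-out higher numbers stand for weaker inhibition and lower numbers for stronger inhibition), compound 1 gives 38 nM. Compound 2 `CN1CC(NC(=O)c2ccncc2Nc2cc(-c3ccc4ccn(C)c4c3)c3nccnc3c2)CCC1=O` carries 1-methyl-6-oxopiperidin-3-yl instead, and in this assay compound 2 gives 116 nM. That swap produced a 3.1-fold higher number from compound 1 to compound 2 (0.48 log units; beyond the scatter), so compound 2 holds the higher of the two numbers and is the weaker inhibitor of the pair.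

Compound 3 `CC(=O)N1CC(NC(=O)c2ccncc2Nc2cc(-c3ccc4ccn(C)c4c3)c3nccnc3c2)C1` has not yet been measured. It is made from compound 2 by one change at the same amide-type nitrogen: 1-acetylazetidin-3-yl in place of 1-methyl-6-oxopiperidin-3-yl on an amide-type nitrogen. Going by the values given here, no measured step covers this exact change; the only step at that position, a 3.1-fold higher number from compound 1 to compound 2 (0.48 log units; beyond the scatter), shows that exchanging one ring for another at this nitrogen moved this assay by a modest amount. A step of comparable size is therefore expected, in either direction, with the estimate kept near the number of compound 2. Compound 3 is expected to give 150 nM, within 50 nM to 500 nM, which means an expected step of a 1.3-fold higher number from compound 2 to compound 3 (0.11 log units; within the scatter).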

Compound 3, half-maximal inhibitory concentration: 73 nM
The estimate for compound 3 lay 2.1-fold (0.31 log units) above the measured number, and the stated range covers the measured number.
By their numbers in this assay, from the lowest: compounds 1, 3 and 2 (each within the scatter of the next, the first and the last beyond it).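

In this assay the exchange of 1-methyl-6-oxopiperidin-3-yl for 1-acetylazetidin-3-yl on the amide-type nitrogen gives a 1.6-fold lower number from compound 2 to compound 3 (0.20 log units; within the scatter) and so shows that a six-membered ring can give way to a four-membered ring here without a change that stands clear of the usual scatter. Going by these compounds alone, the step from the 1-methylpiperidin-4-yl group is also within the scatter, at a 1.9-fold higher number from compound 1 to compound 3 (0.28 log units; within the scatter) and this is new, since the only earlier step at this position, a 3.1-fold higher number from compound 1 to compound 2 (0.48 log units; beyond the scatter) and beyond the scatter, had separated two six-membered rings, whereas the four-membered ring cannot be told apart from either of them in this assay. Nothing measured here gives the reason for any of these steps.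

The compounds shown leave open whether a ring is needed on this nitrogen at all, which an open chain such as 2-methoxyethyl could test. They also leave open what the acetyl group contributes on the four-membered ring, which could be probed by a free amine or a methyl group on that ring nitrogen.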